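The source may hold more compounds than are shown below. What is called first, only, known or untested is meant among the compounds shown, and "the series" means these compounds.

Measured compounds in the series:
compound 1, `Fc1cccc(F)c1CSc1nnc(-c2ccncc2)n1-c1ccccc1`, > 50000 nM
compound 2, `O=[N+]([O-])c1cccc(CSc2nnc(-c3ccncc3)n2-c2ccccc2)c1`, 22000 nM

In a functional assay on HepG2 cells (Homo sapiens) for inhibition, read by MTT assay, with a stated time of 48 h (a higher number here means a weaker inhibitor, a lower number a stronger inhibitor), compound 1 gives > 50000 nM, which is a limit of the assay and not a number. In this assay compound 2 gives 22000 nM. For the measured compounds named here, that is the only number among the two values shown; the other value is a limit, as the line the limit of > 50000 nM in this assay, at which 1 of the 2 values shown sits, records. Going by the values given here, the single measured step, an at least 2.2-fold lower number from compound 1 to compound 2 (0.35 log units; beyond the scatter), is itself bounded on one side by that limit (the limit of > 50000 nM in this assay, at which 1 of the 2 values shown sits), so its true size is unknown beyond the stated minimum.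

Compound 3 is `O=[N+]([O-])c1ccc(CSc2nnc(-c3ccncc3)n2-c2ccccc2)cc1`. It differs from compound 2 by 4-nitrophenyl in place of 3-nitrophenyl on a saturated chain carbon bound to a sulfur. Among the compounds with values here, no measured step moves a nitro group from one position of the phenyl ring to another; the only step on hand exchanges a 2,6-difluorophenyl for a 3-nitrophenyl, a different kind of change, and rests on a limit (the limit of > 50000 nM in this assay, at which 1 of the 2 values shown sits). There is therefore no basis for expecting a step beyond the scatter in this assay, in either direction. The expected step from compound 2 is no change at the digits printed from compound 2 to compound 3 (within the scatter). Compound 3 is estimated at 22000 nM, with a range from 8000 nM to 60000 nM.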

Compound 3, half-maximal inhibitory concentration: > 50000 nM
Compound 3 ended at the assay's limit; the forecaster's own chance of this, stated with the estimate: 30%; middle value at least 2.2-fold (0.35 log units) from the limit.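

In this assay compound 3 gives > 50000 nM, which is a limit of the assay and not a number. Going by these compounds, with the atoms of the group unchanged, 4-nitrophenyl in place of 3-nitrophenyl on a saturated chain carbon bound to a sulfur gives an at least 2.2-fold higher number from compound 2 to compound 3 (0.35 log units; beyond the scatter), so the place of the nitro group on the phenyl ring alone separates a numbered value from a limit, and the true size of this step is unknown beyond its stated minimum. The step between compound 1 and compound 3 cannot be read, and compound 2 remains the only compound of the three with a number: the limit of > 50000 nM in this assay, at which 2 of the 3 values shown sit.

The compounds shown leave open whether the numbered value of compound 2 depends on the nitro group itself or would also be reached with another group at the same place on the phenyl ring, such as an amine or a carboxylic acid. They also leave open how a longer chain between the sulfur and the phenyl ring would read in this assay.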